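The source may report more compounds than this note shows. Statements on the series, on what has been measured and on what is new or still open speak of the compounds shown alone.

Measured in a functional assay on MCF7 cells (Homo sapiens) for antiproliferative activity, read by MTT assay, with a stated time of 72 h; on this read-out lower numbers stand for stronger inhibition and higher numbers for weaker inhibition:
- compound 1 `CC(=O)O[C@H]1CC[C@]2(C)[C@H](CC[C@@](C)(O)[C@H]2CC[C@@H]2C(C)=CC[C@H]3[C@H](CC[C@]3(C)O)C2(C)C)OC1(C)C`: 47900 nM
- compound 2 `CC1=CC[C@H]2[C@H](CC[C@]2(C)O)C(C)(C)[C@@H]1CC[C@H]1[C@]2(C)CC[C@H](OC(=O)c3ccc(C)cc3)C(C)(C)O[C@H]2CC[C@@]1(C)O`: > 50000 nM (a limit)
- compound 3 `CC1=CC[C@H]2[C@@H]1CC=C(C)[C@@H](CC[C@H]1[C@]3(C)CC[C@H](OC(=O)CCC(=O)O)C(C)(C)O[C@H]3CC[C@@]1(C)O)C2(C)C`: > 50000 nM (a limit)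

Compound 3 stands at > 50000 nM, which is a limit and not a number. The next change leads to compound 4 `CC1=CC[C@H]2[C@@H]1CC=C(C)[C@@H](CC[C@H]1[C@]3(C)CC[C@H](OC(=O)c4ccc(Cl)cc4)C(C)(C)O[C@H]3CC[C@@]1(C)O)C2(C)C`: 4-chlorophenyl in place of 2-carboxyethyl on a carbonyl carbon.

For the measured compounds named here, only one measured step bears on this. It is an at least 1.0-fold higher number from compound 1 to compound 2 (0.01 log units; that floor lies within the scatter), with 4-methylphenyl in place of methyl on a carbonyl carbon, and it gives only a floor. Going by the values given here, compound 2, the one measured compound with a substituted phenyl on that carbonyl carbon, is itself a limit at > 50000 nM. The wider picture in this assay is the limit of > 50000 nM in this assay, at which 2 of the 3 values shown sit.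

No large gain is therefore expected, and a report at the limit is quite possible. The expected change is an at least 1.1-fold lower number from compound 3 to compound 4 (0.07 log units; that floor lies within the scatter), small and, if anything, towards a lower number. The estimate for compound 4 is 42000 nM, with an expected range of 18000 nM to 70000 nM.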

Compound 4, half-maximal inhibitory concentration: 22000 nM
Compound 4: middle estimate off by 1.9-fold (0.28 log units), on the high side, and the stated range covers the measured number.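

In this assay, the group on this carbonyl carbon can move the read-out: 4-chlorophenyl in place of 2-carboxyethyl gives an at least 2.2-fold lower number from compound 3 to compound 4 (0.35 log units; beyond the scatter), and this step, unlike the one earlier floor, lies beyond the scatter. Compound 2, which also carries a substituted phenyl on this carbonyl carbon, remains a limit at > 50000 nM. Going by these compounds, a substituted phenyl there therefore does not by itself yield a measured number, and the true size of the step stays unknown, since it is only a floor.

On these data alone, it remains open whether the loss of the carboxylic acid or the entry of the aromatic ring carries the step, the two being exchanged together, and how an amine or a longer chain on this carbonyl carbon would read. Much of the series still stands at a limit: the limit of > 50000 nM in this assay, at which 2 of the 4 values shown sit.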